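The source may hold more compounds than are shown below. What is called first, only, known or untested is meant among the compounds shown, and "the series" means these compounds.

In a functional assay on I10 cells (Mus musculus) for inhibition, read by MTT assay, with a stated time of 72 h (on this read-out lower numbers stand for stronger inhibition and higher numbers for weaker inhibition), compound 1 `C=CCc1ccc(O)c(-c2ccc(OCc3ccccc3)c(CC=C)c2)c1` gives 29800 nM and compound 3 `C=CCc1ccc(OCc2ccc(Cl)cc2Cl)c(-c2ccc(O)c(CC=C)c2)c1` gives 21100 nM, two values within the usual scatter of each other. For compound 2 `C=CCc1ccc(OCc2ccc(Cl)cc2Cl)c(-c2ccc(OCc3ccc(Cl)cc3Cl)c(CC=C)c2)c1` the assay reports only a limit of > 50000 nM. Compound 4 `C=CCc1ccc(O)c(-c2ccc(OCc3ccc(Cl)c(Cl)c3)c(CC=C)c2)c1` has 3,4-dichlorophenyl in place of phenyl on a saturated chain carbon bound to an oxygen on an aromatic ring. Going by the values given here, no measured pair tests this change directly. The closest evidence is the modest at least 2.3-fold lower number from compound 2 to compound 3 (0.37 log units; beyond the scatter), where hydrogen replaces 2,4-dichlorobenzyl. Compound 3 keeps one such chlorinated group and sits at 21100 nM, level with compound 1 within the scatter. In this assay the expected step is therefore a 1.4-fold lower number from compound 1 to compound 4 (0.13 log units; within the scatter), nothing beyond the scatter. For compound 4 the estimated value is 22000 nM, with an expected range from 9000 nM to 45000 nM.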

Compound 4, half-maximal inhibitory concentration: 12300 nM
The estimate for compound 4 lay 1.8-fold (0.25 log units) above the measured number; the measured number falls inside the stated range.
By their numbers in this assay, from the lowest: compounds 4, 3 and 1 (each within the scatter of the next, the first and the last beyond it). At a limit, above all of these: compound 2.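

In this assay, going by these compounds alone, the change from benzyl to 3,4-dichlorobenzyl gives a 2.4-fold lower number from compound 1 to compound 4 (0.38 log units; beyond the scatter) and is the first direct reading of chlorines added to this benzyl group. The earlier step replaced a whole 2,4-dichlorobenzyl group with hydrogen, so it could not show what chlorines on the ring do. No measurement shown accounts for the step.

From the compounds shown here alone, whether one chlorine would give the same step remains open. So does whether methoxy or trifluoromethyl in place of the chlorines would match it.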